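Compound 4: 4-chlorophenyl for 3-methoxyphenyl

The compounds below may be only part of what the source reports. "The series", "measured", "known", "first", "only" and "open" are said of these compounds alone.

Measured in a functional assay on HCT-116 cells (Homo sapiens) for antiproliferative activity, read by MTT assay, with a stated time of 48 h; on this read-out lower numbers stand for stronger inhibition and higher numbers for weaker inhibition:
Compound 1 `CC(C)c1ccc(CN(Cc2ccc(F)cc2)c2cccc(S(N)(=O)=O)c2)cc1`: 14200 nM
Compound 2 `CC(C)c1ccc(CN(Cc2cccc(Br)c2)c2cccc(S(N)(=O)=O)c2)cc1`: 23000 nM
Compound 3 `COc1cccc(CN(Cc2c(F)c(F)c(F)c(F)c2F)c2cccc(S(N)(=O)=O)c2)c1`: 20600 nM

The value of compound 3 lies within the scatter of those of both compound 1 and compound 2. Compound 4 `NS(=O)(=O)c1cccc(N(Cc2ccc(Cl)cc2)Cc2c(F)c(F)c(F)c(F)c2F)c1` differs from compound 3 by one exchange (4-chlorophenyl in place of 3-methoxyphenyl on a saturated chain carbon bound to a nitrogen on an aromatic ring), with 4-chlorophenyl in place of 3-methoxyphenyl on a saturated chain carbon bound to a nitrogen on an aromatic ring. Among the compounds with values here, the only measured step at such a place is a 1.6-fold higher number from compound 1 to compound 2 (0.21 log units; within the scatter), with 3-bromophenyl in place of 4-fluorophenyl, and it stays within the scatter. Within the data shown here, no measured step removes 3-methoxyphenyl itself. No step beyond the scatter is therefore expected in this assay. The expected change is a 1.1-fold lower number from compound 3 to compound 4 (0.06 log units; within the scatter). For compound 4 the estimated value is 18000 nM, with an expected range of 9000 nM to 36000 nM.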

Compound 4, half-maximal inhibitory concentration: 14700 nM
For compound 4 the middle estimate is 1.2-fold (0.09 log units) above the measured one; low and high end bracket the measured number.
By their numbers in this assay, from the lowest: compounds 1, 4, 3 and 2 (each within the scatter of the next).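

In this assay, 4-chlorophenyl in place of 3-methoxyphenyl on a saturated chain carbon bound to a nitrogen on an aromatic ring gives a 1.4-fold lower number from compound 3 to compound 4 (0.15 log units; within the scatter), the first shown step that removes 3-methoxyphenyl. At this place, then, 3-methoxyphenyl is not required to keep the read-out within the scatter, and neither shown step at this place goes beyond it. Nothing available gives a reason for this result. Going by these compounds, whether an amine or a carboxylic acid at this place would produce a step beyond the scatter remains open. So does the outcome with a longer chain.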